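This account rests on a few compounds, and the source may have more. Where it says the series, first, only, none or still open, it means among the compounds named here.

Of the compounds shown here, two have been measured in a functional assay on CHO cells for antagonist activity at metabotropic glutamate receptor 5 (Rattus norvegicus), read by FLIPR and calcium flux; a lower number here means a stronger inhibitor, a higher number a weaker inhibitor. Compound 1 `Cc1ccc2cnc(-c3cccc(Br)c3)nc2n1` gives 38 nM. Compound 2 `N#Cc1cccc(-c2ncc3cccnc3n2)c1` reaches only the limit of this assay, > 26100 nM, so for compound 2 no number is known, just (the limit of > 26100 nM in this assay, at which 1 of the 2 values shown sits). Compound 3 `Brc1cccc(-c2ncc3cccnc3n2)c1` has not yet been measured. It differs from compound 2 in one place: bromo in place of cyano on an aromatic carbon. Apart from the methyl on its core, compound 1 shares this bromo group with compound 3, while compound 2 carries the cyano group and reaches only a limit. The step from compound 2 to compound 3 is therefore expected to be large and towards stronger inhibition, an at least 87-fold lower number from compound 2 to compound 3 (1.93 log units; beyond the scatter). Compound 3 is expected to come in near 300 nM, in a range from 50 nM to 3000 nM, because compound 1 with the same bromo group gives 38 nM.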

Compound 3, half-maximal inhibitory concentration: 333 nM
Compound 3: middle estimate off by 1.1-fold (0.05 log units), on the low side; the range from low to high includes it.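

Swapping cyano for bromo on this aromatic carbon of the six-membered aromatic ring of carbon only gives an at least 78-fold lower number from compound 2 to compound 3 (1.89 log units; beyond the scatter) in this assay, so with the core unchanged, this one group separates a readable inhibitor from none reaching a number. The full size of that step stays unknown, since compound 2 is recorded only as a limit of the assay: the limit of > 26100 nM in this assay, at which 1 of the 3 values shown sits.

The methyl on the core matters as well, though less: hydrogen in place of methyl gives an 8.8-fold higher number from compound 1 to compound 3 (0.94 log units; beyond the scatter), a modest step beside the large one.

The compounds shown leave open how other groups on this aromatic carbon, such as chloro, methoxy or an amine, would compare with bromo. They also leave open whether a longer chain in place of the methyl on the core would move the number further, and whether that methyl would change the result for cyano.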